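Swapping ethoxy for chloro on a benzothiazole pair

The source may report more compounds than this note shows. Statements on the series, on what has been measured and on what is new or still open speak of the compounds shown alone.

Measured compounds:
Compound 1 `Clc1ccc2nc(Nc3nc4ccccc4s3)sc2c1` gives 45400 nM in a functional assay on THP-1 cells (Homo sapiens) for cytotoxicity, read by MTT assay, with a stated time of 48 h; on this read-out higher numbers stand for weaker inhibition and lower numbers for stronger inhibition.
Compound 2 `CCOc1ccc2nc(Nc3nc4ccc(F)cc4s3)sc2c1` gives 39000 nM in this assay.
Compound 3 `CCOc1ccc2nc(Nc3nc4ccccc4s3)sc2c1` gives 37100 nM in this assay.

Compound 2 sits second highest of these three numbers, but its gaps to compound 3 and to compound 1 both fall within the usual scatter, so no ordering among them can be claimed. Compound 4 `Fc1ccc2nc(Nc3nc4ccc(Cl)cc4s3)sc2c1` differs from compound 2 by chloro in place of ethoxy on an aromatic carbon. Among the measured compounds shown here, the one measured step touching this change runs the other way: a 1.2-fold lower number from compound 1 to compound 3 (0.09 log units; within the scatter). Reversing it suggests no shift in this assay beyond the scatter. Compound 4 is therefore expected near 45000 nM, with a range of 20000 nM to 95000 nM, meaning an expected step of a 1.2-fold higher number from compound 2 to compound 4 (0.06 log units; within the scatter).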

Compound 4, half-maximal inhibitory concentration: 41000 nM
For compound 4 the middle estimate is 1.1-fold (0.04 log units) above the measured one; the range from low to high includes it.
By their numbers in this assay, from the lowest: compounds 3, 2, 4 and 1 (each within the scatter of the next).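

With the chloro and ethoxy swap now read on a second core, the step stays small in this assay (a 1.1-fold higher number from compound 2 to compound 4 (0.02 log units; within the scatter)), and the two readings agree: the same change on two cores in this assay, a 1.2-fold lower number (0.09 log units; within the scatter) from compound 1 to compound 3 and a 1.1-fold lower number (0.02 log units; within the scatter) from compound 4 to compound 2, 1.2-fold (0.07 log units) apart, within the scatter of two such steps. Fluoro in place of hydrogen on the other ring also gets a second reading (a 1.1-fold lower number from compound 1 to compound 4 (0.04 log units; within the scatter)), and again the two agree: the same change on two cores in this assay, a 1.1-fold lower number (0.02 log units; within the scatter) from compound 2 to compound 3 and a 1.1-fold higher number (0.04 log units; within the scatter) from compound 4 to compound 1, 1.2-fold (0.07 log units) apart, within the scatter of two such steps. So far, neither change at these places moves the number beyond the scatter on either core.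

From the compounds shown here alone, whether an amine or a carboxylic acid at this place would do so remains open.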